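Fluoro for hydrogen on the pendant phenyl: a second look

The source may hold more compounds than are shown below. What is called first, only, known or untested is meant among the compounds shown, and "the series" means these compounds.

Measured compounds:
compound 1 `COc1cc(NC(C)CCCNC(=O)C2CCC3(CC2)OOC2(OO3)C3CC4CC(C3)CC2C4)c2ncccc2c1-c1ccccc1`, 0.7 h
compound 2 `COc1cc(NC(C)CCCNC(=O)C2CCC3(CC2)OOC2(OO3)C3CC4CC(C3)CC2C4)c2ncccc2c1-c1ccc(F)cc1`, 0.667 h
compound 3 `COc1cc(NC(=O)C2CCC3(CC2)OOC2(OO3)C3CC4CC(C3)CC2C4)c2ncccc2c1-c1ccccc1`, 0.7 h

All three were run in an ADME assay on microsomes from liver (Rattus norvegicus) for metabolic stability, read by HPLC, using NADPH, tested at 1 mM; on this read-out higher numbers stand for a longer-lived compound and lower numbers for a shorter-lived compound. Compound 1 gives 0.7 h, and compound 2 gives 0.667 h; the step between them, a 1.0-fold lower number from compound 1 to compound 2 (0.02 log units; within the scatter), is the change (fluoro in place of hydrogen on an aromatic carbon). Compound 3 gives 0.7 h, which sits level with compound 1 at the digits recorded and within the scatter of compound 2. How the core of compound 3 differs from that of compound 1 is not broken down here.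

The unmeasured compound 4 `COc1cc(NC(=O)C2CCC3(CC2)OOC2(OO3)C3CC4CC(C3)CC2C4)c2ncccc2c1-c1ccc(F)cc1` carries, on the core of compound 3, the change (fluoro in place of hydrogen on an aromatic carbon). The place on the ring is the same, word for word, as for the change from compound 1 to compound 2, so this is the same change made on a second core.

For compound 4 the expected step in this assay is a 1.0-fold lower number from compound 3 to compound 4 (0.02 log units; within the scatter), beside the earlier one, because a 1.0-fold lower number from compound 1 to compound 2 (0.02 log units; within the scatter) was within the scatter and compound 3 starts from 0.7 h. The estimate for compound 4 in this assay is therefore 0.67 h, expected to fall between 0.4 h and 1.1 h.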

Compound 4, half-life: 1 h
Compound 4: middle estimate off by 1.5-fold (0.17 log units), on the low side; low and high end bracket the measured number.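

In this assay the change from phenyl to 4-fluorophenyl gives a 1.4-fold higher number from compound 3 to compound 4 (0.15 log units; within the scatter) on the second core, so neither core shows a step beyond the usual scatter. Set beside the earlier step, the result on the second core does not differ from that on the first: the same change on two cores in this assay, a 1.0-fold lower number (0.02 log units; within the scatter) from compound 1 to compound 2 and a 1.4-fold higher number (0.15 log units; within the scatter) from compound 3 to compound 4, 1.5-fold (0.18 log units) apart, within the scatter of two such steps. Among the compounds shown here, this supports only a limited statement: on these two cores, at this one place on the ring and in this one read-out, the change leaves no step that can be told from scatter, and the two steps can be treated as one result; it does not show that fluoro lengthens or shortens the half-life, that the small gap between the steps is real, or that the same would hold on any further core.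

As far as these compounds go, whether chloro, trifluoromethyl, methoxy or a nitrile at the same place on the pendant phenyl would also leave the half-life within the scatter remains open. Also open, from the compounds shown here alone, is whether the change from phenyl to 4-fluorophenyl would carry over to cores bearing an amine, a carboxylic acid or a longer chain.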